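Propyl Ester Step Carried onto a Second Core

The compounds below may be only part of what the source reports. "The series", "measured", "known", "first", "only" and "open" are said of these compounds alone.

The study covers three measured compounds and one still to be measured, all examined in an assay on HEK-Blue hTLR2 cells for agonist activity at Toll-like receptor 2 (Homo sapiens), with a stated time of 24 h; a lower number here means that less compound is needed, a higher number that more compound is needed for the effect. Compound 1 `COC(=O)c1c(NC(=S)Nc2cccc3ccccc23)sc2c1CCC2` gives 3570 nM. Compound 2 `COC(=O)c1c(NC(=S)Nc2cccc3ccccc23)sc2c1CCCC2` gives 7330 nM, the highest of the three numbers, with compound 1 its nearest neighbour. Compound 3 `CCCOC(=O)c1c(NC(=S)Nc2cccc3ccccc23)sc2c1CCC2` gives 820 nM, the lowest of the set. How the core of compound 1 differs from that of compound 2 is not broken down here.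

Compound 3 arises from compound 1 by ethyl in place of hydrogen on a saturated chain carbon bound to an oxygen next to a carbonyl group, and that change produced a 4.4-fold lower number from compound 1 to compound 3 (0.64 log units; beyond the scatter). Compound 4 `CCCOC(=O)c1c(NC(=S)Nc2cccc3ccccc23)sc2c1CCCC2` stands to compound 2 as compound 3 stands to compound 1: the change is ethyl in place of hydrogen on a saturated chain carbon bound to an oxygen next to a carbonyl group, and it sits in the same place on the other core. Because the earlier step was a 4.4-fold lower number from compound 1 to compound 3 (0.64 log units; beyond the scatter), the expected step for the new pair is estimated at a 4.1-fold lower number from compound 2 to compound 4 (0.61 log units; beyond the scatter), resting on that single precedent alone. On this basis compound 4 is expected to give about 1800 nM, with a range estimated from 900 nM to 3600 nM.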

Compound 4, half-maximal effective concentration: 1050 nM
Compound 4: the middle estimate sits 1.7-fold (0.23 log units) above what was measured; the range from low to high includes it.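

On the core of compound 2, the change from methoxycarbonyl to propoxycarbonyl gave a 7.0-fold lower number from compound 2 to compound 4 (0.84 log units; beyond the scatter) in this assay, the same direction as on the core of compound 1. The change therefore carried from one core to the other in this series, and the two steps cannot be told apart in size: the same change on two cores in this assay, a 4.4-fold lower number (0.64 log units; beyond the scatter) from compound 1 to compound 3 and a 7.0-fold lower number (0.84 log units; beyond the scatter) from compound 2 to compound 4, 1.6-fold (0.21 log units) apart, within the scatter of two such steps

For the compounds shown here, this rests on only one pair of compounds for each core, so it shows agreement between these two cores alone and does not establish that the step would hold on any further core or in any other test. Nor do the numbers say why the propyl ester lowers the number on either core.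

The compounds shown leave open whether the trend continues to a longer chain such as butyl or to a branched chain such as isopropyl at the same place. They also leave open how a carboxylic acid or an amide in place of the ester would behave on either core.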